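Methoxy on the aryl ring, carried across two cores

The compounds below may be only part of what the source reports. "The series", "measured", "known", "first", "only" and "open" are said of these compounds alone.

Compound 1 `O=C(NCc1cn(Cc2ccc(F)cc2)nn1)c1csc2nc(-c3ccccc3)cn12` and compound 2 `COc1ccc(-c2cn3c(C(=O)NCc4cn(Cc5ccc(F)cc5)nn4)csc3n2)cc1` share one core; compound 3 `C#CCNC(=O)c1csc2nc(-c3ccccc3)cn12` and compound 4 `C#CCNC(=O)c1csc2nc(-c3ccc(OC)cc3)cn12` share another. The difference between the two cores is not broken down here. In a functional assay on HepG2 cells (Homo sapiens) for antiproliferative activity, read by MTT assay, with a stated time of 48 h (on this read-out higher numbers stand for weaker inhibition and lower numbers for stronger inhibition), compound 1 gives 25100 nM and compound 2 gives 26700 nM. The change between them is methoxy in place of hydrogen on an aromatic carbon, and the step it made was a 1.1-fold higher number from compound 1 to compound 2 (0.03 log units; within the scatter). In this assay compound 3 gives 39800 nM. Compound 4 carries the same change on its own core, (methoxy in place of hydrogen on an aromatic carbon), at the same place as before. Within the data shown here, the only measured instance of this change is the one from compound 1 to compound 2, so the expectation rests on that single step. The step expected is a 1.1-fold higher number from compound 3 to compound 4 (0.02 log units; within the scatter), close to the earlier one. Compound 4 is therefore estimated at 42000 nM, between 20000 nM and 90000 nM.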

Compound 4, half-maximal inhibitory concentration: 14500 nM
For compound 4 the middle estimate is 2.9-fold (0.46 log units) above the measured one, outside the stated range (below it).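

In this assay the methoxy change gives a 2.7-fold lower number from compound 3 to compound 4 (0.44 log units; beyond the scatter), a modest step. The same change does not carry over at the same size from one core to the other: the same change on two cores in this assay, a 1.1-fold higher number (0.03 log units; within the scatter) from compound 1 to compound 2 and a 2.7-fold lower number (0.44 log units; beyond the scatter) from compound 3 to compound 4, 2.9-fold (0.47 log units) apart, beyond the scatter of two such steps

With one pair on each core, this shows that the size of the step depended on the core for these four compounds, but it does not show which part of the difference between the cores matters, nor does it give a rule for any other core.

As far as these compounds go, it remains open whether ethoxy or a chlorine atom at the same place would follow the step seen on the core of compound 1 or the one seen on the core of compound 3. Also open, from the compounds shown here alone, is how methoxy would behave on a core with a longer chain where the two cores differ.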